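Swapping the pyrazole of compound 1 for a thiazole

The compounds below may be only part of what the source reports. "The series", "measured", "known", "first", "only" and "open" are said of these compounds alone.

Among the compounds with values here, compound 1 `Cc1cnn(-c2ccncc2N2CCC(C(=O)N(C)C)CC2)c1` gives the lowest of the two numbers measured so far in an assay on HEK293F cells for inhibition of cholesterol 24-hydroxylase (Homo sapiens), read by trypan blue exclusion, with stated times of 15 min and 5 h (on this read-out lower numbers stand for stronger inhibition and higher numbers for weaker inhibition), with 8.5 nM. Its nearest neighbour is compound 2 `CN(C)C(=O)C1CCN(c2cnccc2-n2cc(C(F)(F)F)cn2)CC1`, which in this assay gives 65 nM; the step of a 7.6-fold higher number from compound 1 to compound 2 (0.88 log units; beyond the scatter) came from trifluoromethyl in place of methyl on an aromatic carbon. Compound 3 `Cc1cnc(-c2ccncc2N2CCC(C(=O)N(C)C)CC2)s1` differs from compound 1 in another way: 5-methyl-1,3-thiazol-2-yl in place of 4-methyl-1H-pyrazol-1-yl on an aromatic carbon. Within the data shown here, no measured step exchanges this ring itself; the only recorded step alters a substituent on the group that now leaves, so it informs the new change only indirectly, showing that this part of the molecule can shift the number by a modest amount. A shift of similar size is therefore expected, more probably toward a higher number, as a 2.9-fold higher number from compound 1 to compound 3 (0.47 log units; beyond the scatter). For compound 3 the estimate is 25 nM, within 6 nM to 120 nM.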

Compound 3, half-maximal inhibitory concentration in the cholesterol 24-hydroxylase assay: 12 nM
Compound 3: the middle estimate sits 2.1-fold (0.32 log units) above what was measured; low and high end bracket the measured number.
By their numbers in the cholesterol 24-hydroxylase assay, from the lowest: compounds 1 and 3 (each within the scatter of the next); then compound 2.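

In the cholesterol 24-hydroxylase assay the aromatic carbon opposite the ring nitrogen accepts 5-methyl-1,3-thiazol-2-yl in place of 4-methyl-1H-pyrazol-1-yl with no change beyond the scatter, as a 1.4-fold higher number from compound 1 to compound 3 (0.15 log units; within the scatter) shows. Within the data shown here, the earlier step, a 7.6-fold higher number from compound 1 to compound 2 (0.88 log units; beyond the scatter), had altered only a substituent on the pyrazole, so this is the first sign that the whole ring can be exchanged here and the number hold. The exchange does register in lipophilicity, as read in a physicochemical assay for lipophilicity, at pH 7.4 (on this read-out higher numbers stand for higher lipophilicity and lower numbers for lower lipophilicity), where compound 1 gives 1.6 and compound 3 gives 2: the measured distribution coefficient of compound 1, 1.6, and of compound 3, 2, a number 0.40 log units higher (beyond the scatter)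

The compounds shown leave open whether trifluoromethyl in place of methyl would cost as much on the thiazole as it did on the pyrazole. They also leave open how a nitrile or a primary amine on that ring would fare in either read-out.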